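A few compounds are considered here, and "the series" means these few. Any claim that something is new, unique, unknown or untested is made for them only; others in the source may bear on it.

Measured so far in a functional assay on HCT-116 cells (Homo sapiens), read by fluorescence and BrdU incorporation, with a stated time of 48 h, tested at 10 uM; a lower number here means a stronger effect, a higher number a weaker effect of the compound at the concentration tested:
- compound 1, `COc1cccc(/C=C/C(=O)c2c(OC)cc(OC)cc2OC)c1`, gives 20%
- compound 2, `COc1cc(O)c(C(=O)/C=C/c2ccccc2OC)c(OC)c1`, gives 42%

Compound 1 stands at the lowest of the two numbers shown; compound 2 comes out higher by an amount beyond the scatter, so compound 1 has the stronger effect of the two. The unmeasured compound 3, `COc1cc(OC)c(C(=O)/C=C/c2ccc(Cl)cc2)c(OC)c1`, keeps the core of compound 1 and differs in a single place: 4-chlorophenyl in place of 3-methoxyphenyl on a double-bonded chain carbon bound to a double-bonded chain carbon. Within the data shown here, no pair of measured compounds shows what such a swap does, so the expectation rests on compound 1 alone. The leaving group carries a hydrogen-bond acceptor while the entering group carries none. Compound 3 is expected to land close to compound 1 or somewhat weaker, a step of a number 10 percentage points higher from compound 1 to compound 3 (within the scatter) in this assay that may well stay within the scatter. Compound 3 is estimated at 30%, with a range from 10% to 55%.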

Compound 3, a percentage reported as activity, at one concentration (the size of the read-out at that concentration, not a potency): 18%
For compound 3 the middle estimate is 12 percentage points above the measured one, within the range that was stated.
By their numbers in this assay, from the lowest: compounds 3 and 1 (each within the scatter of the next); then compound 2.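

At the double-bonded chain carbon bound to a double-bonded chain carbon, putting 4-chlorophenyl in place of 3-methoxyphenyl gives, in this assay, a number 2 percentage points lower from compound 1 to compound 3 (within the scatter), so the two groups cannot be told apart here. The leaving group carries a hydrogen-bond acceptor and the entering group carries none, so in this pair the read-out holds without an acceptor on that ring. No measurement on hand offers a reason for this match.

From the compounds shown here alone, whether a ring carrying an amine or a carboxylic acid, or a longer chain in place of the ring, would also hold the read-out stays open. A plain phenyl at this place would show whether the chlorine or the methoxy matters at all, and that too remains unanswered.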